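Fluoro to 2-fluoroethoxy on a shared amide core

A few compounds are considered here, and "the series" means these few. Any claim that something is new, unique, unknown or untested is made for them only; others in the source may bear on it.

Compound 1 `Cc1cnc(C(=O)Nc2cc(F)cc3cccnc23)cn1`: in a functional assay on BXPC-3 cells (Homo sapiens) for inhibition, read by MTT assay, with a stated time of 72 h (a higher number here means a weaker inhibitor, a lower number a stronger inhibitor), compound 1 gives > 10000 nM, a limit of the assay.
Compound 2 `O=C(Nc1cc(F)cc2cccnc12)c1cnccn1`: compound 2 gives > 10000 nM, again a limit.
Compound 3 `O=C(Nc1cc(F)cc2cccnc12)c1ncccn1`: compound 3 gives > 10000 nM, also a limit.

Compound 2 therefore stands only at a limit, as do the other two; all three values sit at the limit of > 10000 nM in this assay, at which 3 of the 3 values shown sit. The measured steps a step that the two limits leave unreadable from compound 1 to compound 2, a step that the two limits leave unreadable from compound 1 to compound 3 and a step that the two limits leave unreadable from compound 2 to compound 3 are unreadable between two limits. Compound 4 `O=C(Nc1cc(OCCF)cc2cccnc12)c1cnccn1` differs from compound 2 by 2-fluoroethoxy in place of fluoro on an aromatic carbon. Among the compounds with values here, none of the measured steps gives a readable size, so the step from compound 2 to compound 4 is expected to be an at least 1.1-fold lower number from compound 2 to compound 4 (0.04 log units; that floor lies within the scatter), no step beyond the scatter. Compound 4 is estimated at 9000 nM, expected between 2000 nM and 40000 nM.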

Compound 4, half-maximal inhibitory concentration: 4330 nM
Compound 4: middle estimate off by 2.1-fold (0.32 log units), on the high side; the range from low to high includes it.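

Replacing fluoro with 2-fluoroethoxy on the aromatic carbon para to a fused ring gives in this assay a readable result: an at least 2.3-fold lower number from compound 2 to compound 4 (0.36 log units; beyond the scatter). The steps among compound 1, compound 2 and compound 3 cannot be read, so this position is the first shown to respond. The full size of the step stays unknown because compound 2 sits at a limit: the limit of > 10000 nM in this assay, at which 3 of the 4 values shown sit.

On these data alone, whether a longer chain, a methoxy group or an amine at this position would move the value further remains open. So does whether 2-fluoroethoxy acts the same way with the pyrimidin-2-yl or 5-methylpyrazin-2-yl group on the carbonyl carbon.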